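Ethyl to isopropyl on the amine of compound 3

A few compounds are considered here, and "the series" means these few. Any claim that something is new, unique, unknown or untested is made for them only; others in the source may bear on it.

Measured so far:
compound 1, `CCNC(c1ccnc(Nc2ccc(C#N)cc2)n1)c1ccccc1Cl`, 39400 nM
compound 2, `CCCNC(c1ccc(C#N)cc1)c1ccnc(Nc2ccc(C#N)cc2)n1`, 34900 nM
compound 3, `CCNC(c1ccc(/C=C/C#N)cc1)c1ccnc(Nc2ccc(C#N)cc2)n1`, 37300 nM

All three values come from an ADME assay on MT4 cells (Homo sapiens) for cytotoxicity, read by MTT assay, with a stated time of 5 days; a lower number here means that less compound is tolerated, a higher number that more compound is tolerated. Compound 3 sits second highest of the three numbers, but its nearest neighbour, compound 1, and its furthest, compound 2, both lie within the usual scatter of such measurements, so the three compounds cannot be told apart on this read-out. Each carries the shared core with the nitrile-bearing aniline, and each tolerates roughly the same amount of compound in this assay.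

Compound 4, `CC(C)NC(c1ccc(/C=C/C#N)cc1)c1ccnc(Nc2ccc(C#N)cc2)n1`, differs from compound 3 in one place: methyl in place of hydrogen on a saturated chain carbon bound to an amine nitrogen and a saturated chain carbon. The amine side chain grows from ethylamino to isopropylamino. Among the measured compounds shown here, nothing among the measured compounds speaks for a change beyond the scatter from such a small addition, and compound 2, which carries a longer propylamino chain, gives a number no different from the others. The expected step from compound 3 to compound 4 in this assay is therefore none beyond the scatter, a 1.0-fold lower number from compound 3 to compound 4 (0.02 log units; within the scatter). Compound 4 is estimated at 36000 nM, within a range of 18000 nM to 72000 nM.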

Compound 4, half-maximal cytotoxic concentration: 32300 nM
Beside the measured number, compound 4's estimate is 1.1-fold (0.05 log units) above it; the range from low to high includes it.
By their numbers in this assay, from the lowest: compounds 4, 2, 3 and 1 (each within the scatter of the next).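

In this assay, a 1.2-fold lower number from compound 3 to compound 4 (0.06 log units; within the scatter), so adding one methyl in place of hydrogen on a saturated chain carbon bound to an amine nitrogen and a saturated chain carbon produces no change that can be told from the ordinary variation between repeated measurements. This is the first pair shown that differs in only one place, so it gives the first direct reading for this position, which compounds 1, 2 and 3 could not give on their own: going from ethylamino to isopropylamino leaves this cell read-out effectively unchanged. No supporting measurement bears on why the number holds steady here.

This single small step cannot show whether the position stays just as flat with much larger or differently built groups on the amine nitrogen, such as a benzyl group, a cyclohexyl ring or a chain ending in a carboxylic acid. From the compounds shown here alone, a free amine, with no carbon group on that nitrogen at all, is equally open, and so is whether the same ethyl to isopropyl change would stay within the scatter on a different core.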